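Bromo to methoxy on the pendant phenyl of compound 3

A few compounds are considered here, and "the series" means these few. Any claim that something is new, unique, unknown or untested is made for them only; others in the source may bear on it.

Among the measured compounds shown here, compound 3 `Cn1ccc2c(Oc3ccc(NC(=O)c4cc5cccnc5n(-c5ccc(Br)cc5)c4=O)cc3F)ccnc21` gives 330 nM in a functional assay on HT-29 cells (Homo sapiens) for antiproliferative activity, read by MTT assay, with a stated time of 72 h (on this read-out lower numbers stand for stronger inhibition and higher numbers for weaker inhibition), and stands second highest of the three numbers so far. Compound 2 `Cn1ccc2c(Oc3ccc(NC(=O)c4cc5cccnc5n(-c5ccc(F)cc5)c4=O)cc3F)ccnc21` gives 160 nM in this assay, and compound 1 `COc1ccc(-n2c(=O)c(C(=O)Nc3ccc(Oc4ccnc5[nH]ccc45)c(F)c3)cc3cccnc32)cc1` gives 540 nM. Compound 3 lies nearest compound 1, within the scatter, and furthest from compound 2, beyond it.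

Compound 4 `COc1ccc(-n2c(=O)c(C(=O)Nc3ccc(Oc4ccnc5c4ccn5C)c(F)c3)cc3cccnc32)cc1` differs from compound 3 in one place: methoxy in place of bromo on an aromatic carbon. For the measured compounds named here, no measured step exchanges bromo for methoxy. Compound 1 carries the methoxy but differs from compound 3 in a second place as well, so the two values show only a gap within the scatter. Going by the values given here, the single step at this position, a 2.1-fold higher number from compound 2 to compound 3 (0.31 log units; beyond the scatter), was modest. For compound 4 the expected step is therefore a 1.1-fold lower number from compound 3 to compound 4 (0.04 log units; within the scatter), close to the scatter and without a firm direction. The estimate for compound 4 in this assay is 300 nM, with a range from 120 nM to 750 nM.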

Compound 4, half-maximal inhibitory concentration: 1290 nM
Compound 4: the middle estimate sits 4.3-fold (0.63 log units) below what was measured; measured number outside the range, above it.
By their numbers in this assay, from the lowest: compound 2; then compounds 3 and 1 (each within the scatter of the next); then compound 4.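

In this assay fluoro, bromo and methoxy on the phenyl now form a series of three at this position, with a 2.1-fold higher number from compound 2 to compound 3 (0.31 log units; beyond the scatter) for the halogen exchange, a 3.9-fold higher number from compound 3 to compound 4 (0.59 log units; beyond the scatter) for bromo to methoxy and an 8.1-fold higher number from compound 2 to compound 4 (0.91 log units; beyond the scatter) across the whole series. With the 4-methoxyphenyl held fixed, methyl in place of hydrogen on the aromatic nitrogen gives a 2.4-fold higher number from compound 1 to compound 4 (0.38 log units; beyond the scatter) as a separate step beyond the scatter. The data shown give no reason for either change.

Hydrogen on the aromatic nitrogen appears here only with the 4-methoxyphenyl, so it remains open whether the order of fluoro, bromo and methoxy holds with that nitrogen unsubstituted. An amine or a carboxylic acid at the same place on the phenyl, or a longer chain on that nitrogen, would test how far both trends extend.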